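Three phenoxy replacements on one aspartyl ketone core

A few compounds are considered here, and "the series" means these few. Any claim that something is new, unique, unknown or untested is made for them only; others in the source may bear on it.

Compound 1 `CC(C)[C@H](NC(=O)COc1cccc2ccccc12)C(=O)N[C@@H](CC(=O)O)C(=O)COC(=O)c1c(Cl)cccc1Cl` gives 11500 nM in a functional assay with Homo sapiens as the target; a higher number here means a weaker inhibitor, a lower number a stronger inhibitor.
Compound 2 `CC(C)[C@H](NC(=O)COc1cccc2ccccc12)C(=O)N[C@@H](CC(=O)O)C(=O)COc1ccc(F)c(F)c1F` gives 20600 nM in this assay.
Compound 3 `CC(C)[C@H](NC(=O)COc1cccc2ccccc12)C(=O)N[C@@H](CC(=O)O)C(=O)COc1cc(F)c(F)cc1F` gives 16700 nM in this assay.

Among these three, compound 1 has the lowest number, but its neighbours sit close: the step of a 1.5-fold higher number from compound 1 to compound 3 (0.16 log units; within the scatter) and the step of a 1.8-fold higher number from compound 1 to compound 2 (0.25 log units; within the scatter) both fall within the scatter, so no ordering of the three can be asserted.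

Compound 4 `CC(C)[C@H](NC(=O)COc1cccc2ccccc12)C(=O)N[C@@H](CC(=O)O)C(=O)COc1c(F)cc(F)cc1F` has not been measured. It differs from compound 1 in one place (2,4,6-trifluorophenyl in place of (2,6-dichlorophenyl)carbonyl on an oxygen on a saturated carbon). The two measured steps that bear on this change are the ones from compound 1 to compound 2 and from compound 1 to compound 3, since each replaces the same leaving group with a trifluorophenyl that differs only in the positions of its three fluorines; both landed within the scatter, as did the step of a 1.2-fold lower number from compound 2 to compound 3 (0.09 log units; within the scatter) between the two fluorine patterns. A third fluorine pattern is therefore expected to behave alike, with no step beyond the scatter.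

Compound 4 is thus estimated at 17000 nM, within a range from 8500 nM to 36000 nM, which corresponds to an expected step of a 1.5-fold higher number from compound 1 to compound 4 (0.17 log units; within the scatter).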

Compound 4, half-maximal inhibitory concentration: 14900 nM
Beside the measured number, compound 4's estimate is 1.1-fold (0.06 log units) above it; the measured number falls inside the stated range.
By their numbers in this assay, from the lowest: compounds 1, 4, 3 and 2 (each within the scatter of the next).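

With compound 4, the change on this oxygen has now been read for three fluorine patterns: in this assay, 2,4,6-trifluorophenyl in place of (2,6-dichlorophenyl)carbonyl gives a 1.3-fold higher number from compound 1 to compound 4 (0.11 log units; within the scatter), so this third pattern also cannot be told apart from the carbonyl-linked group. The fluorine patterns also stay unresolved from one another, with a 1.1-fold lower number from compound 3 to compound 4 (0.05 log units; within the scatter) and a 1.4-fold lower number from compound 2 to compound 4 (0.14 log units; within the scatter), so all three pairings of the trifluorophenyl groups now lie within the scatter and the position of the fluorines shows no measurable effect in these compounds. Nothing measured alongside these numbers explains why the values at this position stay so close together.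

Every group shown on this oxygen carries one six-membered aromatic ring of carbon only, so it remains open whether an unsubstituted phenyl, a saturated chain such as butyl, or a chain ending in an amine would move the number beyond the scatter. On these data alone, it also remains open whether this flat response would persist with a methyl ester in place of the carboxylic acid of the shared core.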